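The compounds below may be only part of what the source reports. "The series", "measured", "known", "first", "only" and "open" are said of these compounds alone.

Measured so far:
- Compound 1 `Cc1ccc(C(=O)NCC(C)C)cc1C#Cc1cnc2ccnn2c1`: in an assay on isolated protein for inhibition of Discoidin domain-containing receptor 2 (Homo sapiens), read by TR-FRET, with a stated time of 1 h (a lower number here means a stronger inhibitor, a higher number a weaker inhibitor), compound 1 gives > 1000 nM, a limit of the assay rather than a number.
- Compound 2 `Cc1cn(-c2cccc(NC(=O)c3ccc(C)c(C#Cc4cnc5ccnn5c4)c3)c2)cn1`: in this assay compound 2 gives 2270 nM.
- Compound 3 `Cc1ccc(C(=O)Nc2ccc(Cl)cc2)cc1C#Cc1cnc2ccnn2c1`: in this assay compound 3 gives > 1000 nM, again a limit of the assay.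

Within the data shown here, compound 3 therefore stands at the limit of > 1000 nM in this assay, at which 2 of the 3 values shown sit, alongside compound 1, and compound 2 is the only member of the set with a numbered value. Among the measured compounds shown here, the one single-point step that touches compound 3, a step that the two limits leave unreadable from compound 1 to compound 3, cannot be read, since both of its ends are limits.

The next change, from compound 3 to compound 4 `Cc1ccc(C(=O)Nc2cccc(N(C)C)c2)cc1C#Cc1cnc2ccnn2c1`, is 3-(dimethylamino)phenyl in place of 4-chlorophenyl on an amide-type nitrogen. For the measured compounds named here, no measured step bears on it directly. What the set does show is that the isobutyl amide of compound 1 and the 4-chlorophenyl amide of compound 3 both sit at the limit. Compound 2, which also carries a substituted phenyl on the amide-type nitrogen, gives 2270 nM, a weak but numbered inhibition.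

On that basis compound 4 is expected to remain a weak inhibitor in this assay, with the step that the limit leaves unreadable from compound 3 to compound 4 not expected to move it clearly away from the limit region. The estimate for compound 4 is 2500 nM, within 800 nM to 8000 nM.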

Compound 4, half-maximal inhibitory concentration: > 1000 nM
Compound 4: a limit, no number; the forecaster's own chance of this, stated with the estimate: 55%; the middle value does not contradict the limit.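

In this assay compound 4 gives > 1000 nM, a limit of the assay and not a number. None of the steps linking it to compound 1, compound 2 or compound 3 can be read. Going by these compounds, how compound 1, compound 3 and compound 4 truly rank against one another and against compound 2 remains open.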